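A few compounds are considered here, and "the series" means these few. Any claim that something is new, unique, unknown or untested is made for them only; others in the source may bear on it.

Measured so far
- compound 1, `O=C1O/C(=C\Cn2cc(-c3cc(F)cc(F)c3)nn2)C(OCc2ccccc2)=C1OCc1ccccc1`: in a functional assay on HCT-116 cells (Homo sapiens) for antiproliferative activity, read by MTT assay, with a stated time of 72 h (on this read-out lower numbers stand for stronger inhibition and higher numbers for weaker inhibition), compound 1 gives > 100000 nM, which is a limit of the assay and not a number.
- compound 2, `CC(C)(C)OC(=O)N1CCN(C(=S)SCc2cn(C[C@H](O)[C@H]3OC(=O)C(OCc4ccccc4)=C3OCc3ccccc3)nn2)CC1`: compound 2 gives > 100000 nM, again a limit of the assay.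
- compound 3, `COc1ccccc1-c1cn(C[C@H](O)[C@H]2OC(=O)C(OCc3ccccc3)=C2OCc2ccccc2)nn1`: compound 3 gives > 100000 nM, also a limit of the assay.

Every value shown sits at the limit of > 100000 nM in this assay, at which 3 of the 3 values shown sit. Within the data shown here, compound 3 therefore cannot be placed on a scale: its own result is a limit, and the two other results in this assay are limits too, so no ordering among compounds 1, 2 and 3 can be read and no step between measured compounds is available to set a size.

Compound 4, `C[Si](C)(C)c1cn(C[C@H](O)[C@H]2OC(=O)C(OCc3ccccc3)=C2OCc2ccccc2)nn1`, differs from compound 3 only by a group of 4 heavy atoms (3 carbon, 1 silicon; no ring) in place of a group of 8 heavy atoms (7 carbon, 1 oxygen; one six-membered aromatic ring of carbon only), on an aromatic carbon. With nothing but limits in hand, no direction for this change can be drawn from the series; the working expectation is that the step that the limit leaves unreadable from compound 3 to compound 4 is none beyond the scatter, and that compound 4 will most likely also return a limit. Compound 4 is estimated at 150000 nM, with a range from 40000 nM to 600000 nM.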

Compound 4, half-maximal inhibitory concentration: 31800 nM
Estimate against measurement, compound 4: 4.7-fold (0.67 log units) above, and the stated range ends above it.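

In this assay the replacement of 2-methoxyphenyl by a group of 4 heavy atoms (3 carbon, 1 silicon; no ring) gives an at least 3.1-fold lower number from compound 3 to compound 4 (0.49 log units; beyond the scatter) and yields the first result in the series that is a number and not a limit. This aromatic carbon of the five-membered aromatic ring with 3 nitrogen is therefore a place where a change of group can register, and for this pair the six-membered aromatic ring is not needed for a readable value. The true size of the step stays unknown because compound 3 gives only a limit of the assay: the limit of > 100000 nM in this assay, at which 3 of the 4 values shown sit.

From the compounds shown here alone, whether the silicon atom or the loss of the ring drives the change stays open, as does the outcome with a tert-butyl group, an amine or a carboxylic acid at this place. Steps among the compounds that give only limits cannot be read, and a single numerical value sets no trend.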